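Swapping a Benzofuran for a Carboxyphenoxy Group

The source may hold more compounds than are shown below. What is called first, only, known or untested is meant among the compounds shown, and "the series" means these compounds.

Three compounds have been measured in an assay on isolated protein for agonist activity at Bile acid receptor (Homo sapiens), read by AlphaScreen, with a stated time of 30 min; a higher number here means that more compound is needed for the effect, a lower number that less compound is needed:

Compound 1 `Cc1ccc(-n2nc(C)c3c2NC(=O)[C@H](C)S[C@@H]3c2ccc(Oc3ccccc3)cc2)cc1` gives 3400 nM.
Compound 2 `Cc1ccccc1-n1nc(C)c2c1NC(=O)[C@H](C)S[C@@H]2c1ccc(-c2cc3ccccc3o2)cc1` gives 1500 nM.
Compound 3 `Cc1nn(-c2ccccc2C(C)C)c2c1[C@@H](c1ccc(Oc3ccccc3)cc1)S[C@@H](C)C(=O)N2` gives 1900 nM.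

Compound 2 has the lowest number of the three. Its gap to compound 3 lies within the usual scatter, so no order between those two can be read; its gap to compound 1 lies beyond the scatter, with compound 1 at the higher number. Compound 4 `Cc1ccccc1-n1nc(C)c2c1NC(=O)[C@H](C)S[C@@H]2c1ccc(Oc2ccc(C(=O)O)cc2)cc1` has not yet been measured in this assay. It differs from compound 2 in one place: 4-carboxyphenoxy in place of 1-benzofuran-2-yl on an aromatic carbon.

For the measured compounds named here, the only single-change step among the measured compounds is a 1.8-fold lower number from compound 1 to compound 3 (0.25 log units; within the scatter), and it concerns the group on the aromatic nitrogen, so it does not bear on the change made here. Compounds 1 and 3 carry a phenoxy group at the changed place, but each also differs from compound 2 at the aromatic nitrogen, so their numbers can only hint that phenoxy-type groups sit at somewhat higher numbers than the benzofuran of compound 2.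

The step is expected to be a 1.7-fold higher number from compound 2 to compound 4 (0.22 log units; within the scatter), a moderate rise with wide uncertainty. Compound 4 is therefore expected at 2500 nM, within a range from 800 nM to 8000 nM.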

Compound 4, half-maximal effective concentration: "not active" (no number reported)
Compound 4 has no reported number here, so the estimate cannot be set against anything.
By their numbers in this assay, from the lowest: compounds 2, 3 and 1 (each within the scatter of the next, the first and the last beyond it).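

In this assay, for the compounds shown here, compound 4 is reported as not active, without a number, so no step from compound 2 to compound 4 can be read. The compounds shown leave open how far apart these two lie, and which part of the 4-carboxyphenoxy group matters; nothing measured here points to a cause.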